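The source may hold more compounds than are shown below. What is called first, only, known or untested is meant among the compounds shown, and "the series" means these compounds.

Measured in a functional assay on MIA PaCa-2 cells (Homo sapiens) for antiproliferative activity, read by sulforhodamine B assay, with a stated time of 48 h; on this read-out lower numbers stand for stronger inhibition and higher numbers for weaker inhibition:
- compound 1 `COc1cc(OC)c2sc(-c3ccc(N/C=C\C(=O)c4ccc(OC)c(O)c4)c(C)c3)nc2c1`: 22100 nM
- compound 2 `COc1cc(OC)c2sc(-c3ccc(N/C=C\C(=O)c4ccc(OC)c(O)c4)cc3)nc2c1`: 11600 nM
- compound 3 `COc1ccc2nc(-c3ccc(N/C=C\C(=O)c4ccc(OC)c(F)c4)cc3)sc2c1`: 1300 nM

Compound 1 sits at the high, weak end of these numbers, level with compound 2 once the scatter is allowed for, and well above compound 3.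

Compound 4 `COc1cc(OC)c2sc(-c3ccc(N/C=C\C(=O)c4ccc(OC)c(F)c4)c(C)c3)nc2c1` is compound 1 with fluoro in place of hydroxy on an aromatic carbon, turning the 3-hydroxy-4-methoxyphenyl into 3-fluoro-4-methoxyphenyl: fluoro in place of hydroxy on an aromatic carbon.

Within the data shown here, no measured pair isolates this swap. Among the measured compounds shown here, the one measured step, a 1.9-fold lower number from compound 1 to compound 2 (0.28 log units; within the scatter), concerns a methyl group elsewhere and says little here. The better clue is compound 3, which already carries the 3-fluoro-4-methoxyphenyl group and gives 1300 nM. Its core differs from that of compound 1, however, so only part of that gap can be expected to carry over.

A move toward stronger inhibition is therefore expected, of uncertain size, and the estimated change is a 3.7-fold lower number from compound 1 to compound 4 (0.57 log units; beyond the scatter). For compound 4 the estimated value is 6000 nM, with an expected range from 1500 nM to 22000 nM.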

Compound 4, half-maximal inhibitory concentration: 16300 nM
Estimate against measurement, compound 4: 2.7-fold (0.43 log units) below, and the stated range covers the measured number.
By their numbers in this assay, from the lowest: compound 3; then compounds 2, 4 and 1 (each within the scatter of the next).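

In this assay, fluoro in place of hydroxy on the aromatic carbon gives a 1.4-fold lower number from compound 1 to compound 4 (0.13 log units; within the scatter), so this swap makes no readable difference on this core. The hydroxy brings a hydrogen-bond donor and acceptor and the fluoro brings neither, yet losing them does not show in this read-out, so at this place on compound 1 the hydroxy is not required for the activity seen. Nothing at hand explains why the two groups read alike.

An amine, a chloro group or a plain hydrogen at this place could still separate from hydroxy and fluoro. On these data alone, it also stays open whether the same swap would read alike on the core of compound 2 or compound 3.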